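Enone ester series: aryl swap at the chain carbon

The compounds below may be only part of what the source reports. "The series", "measured", "known", "first", "only" and "open" are said of these compounds alone.

Measured so far in a functional assay on T47D cells (Homo sapiens) for inhibition, read by sulforhodamine B assay, with a stated time of 48 h; on this read-out lower numbers stand for stronger inhibition of growth and higher numbers for weaker inhibition of growth:
compound 1 `CC(=O)OC/C(=C\c1ccccc1[N+](=O)[O-])C(=O)c1ccccc1`, 21000 nM
compound 2 `O=C(OC/C(=C\C1CCCCC1)C(=O)c1ccccc1)c1ccccc1`, 20000 nM
compound 3 `O=C(OC/C(=C\c1ccc(Cl)cc1Cl)C(=O)c1ccccc1)c1ccccc1`, 17000 nM

Compound 3 gives the lowest of the three numbers, but its gaps to compound 2 and to compound 1 both lie within the scatter, so no order among the three is claimed. Compound 4 `O=C(OC/C(=C\c1ccccc1[N+](=O)[O-])C(=O)c1ccccc1)c1ccccc1` differs from compound 3 by 2-nitrophenyl in place of 2,4-dichlorophenyl on a double-bonded chain carbon bound to a double-bonded chain carbon. Within the data shown here, the one measured step at this position, a 1.2-fold lower number from compound 2 to compound 3 (0.07 log units; within the scatter), stayed within the scatter. Compound 1 carries the same 2-nitrophenyl group with a different ester and sits close to compound 3 in this assay. For the step itself, the expectation is a 1.2-fold higher number from compound 3 to compound 4 (0.07 log units; within the scatter), nothing beyond the scatter. Compound 4 is therefore estimated at 20000 nM, with a range from 10000 nM to 40000 nM.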

Compound 4, concentration for 50% growth inhibition: 16000 nM
For compound 4 the middle estimate is 1.3-fold (0.10 log units) above the measured one, and the stated range covers the measured number.
By their numbers in this assay, from the lowest: compounds 4, 3, 2 and 1 (each within the scatter of the next).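

In this assay the step to 2-nitrophenyl from 2,4-dichlorophenyl on a double-bonded chain carbon is a 1.1-fold lower number from compound 3 to compound 4 (0.03 log units; within the scatter) and the step to 2-nitrophenyl from cyclohexyl is a 1.3-fold lower number from compound 2 to compound 4 (0.10 log units; within the scatter) so all three groups at this position now lie within the scatter of one another. Phenyl in place of methyl on a carbonyl carbon, a second place of change, gives a 1.3-fold lower number from compound 1 to compound 4 (0.12 log units; within the scatter) and so also leaves the number within the scatter. No evidence is at hand that bears on this result. Going by these compounds, whether an amine or a carboxylic acid at the chain carbon, or a longer chain in place of phenyl on the carbonyl carbon, would move the number beyond the scatter stays open.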